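Acetylation of an Aromatic Amine Across Two Related Cores

The source may hold more compounds than are shown below. What is called first, only, known or untested is meant among the compounds shown, and "the series" means these compounds.

The measure used here is a functional assay on PLC-PRF-5 cells (Homo sapiens) for inhibition; a lower number here means a stronger inhibitor, a higher number a weaker inhibitor. Compound 1, `Cc1cc(Oc2ccnc3c(N)cccc23)ccc1NC(=O)c1cc(C(F)(F)F)cc(C(F)(F)F)c1`, carries a free amino group on its aromatic ring, and in this assay compound 1 gives 25400 nM. Compound 2, `CC(=O)Nc1cccc2c(Oc3ccc(NC(=O)c4cc(C(F)(F)F)cc(C(F)(F)F)c4)c(C)c3)ccnc12`, differs from it by acetyl in place of hydrogen on a nitrogen on an aromatic ring. For compound 2 the result in this assay is only a limit of the assay, > 40000 nM, not a number. The step of an at least 1.5-fold higher number from compound 1 to compound 2 (0.19 log units; that floor lies within the scatter) therefore has a floor rather than a fixed size, set by the limit of > 40000 nM in this assay, at which 1 of the 3 values shown sits.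

Compound 3, `Nc1cccc2c(Oc3cccc(NC(=O)c4cc(C(F)(F)F)cc(C(F)(F)F)c4)c3)ccnc12`, sits on a related core; the difference between the two cores is not broken down here. In this assay compound 3 gives 19000 nM, a value that lies within the usual scatter of the value of compound 1, so the two cannot be put in order.

Going by the values given here, compound 4, `CC(=O)Nc1cccc2c(Oc3cccc(NC(=O)c4cc(C(F)(F)F)cc(C(F)(F)F)c4)c3)ccnc12`, differs from compound 3 by acetyl in place of hydrogen on a nitrogen on an aromatic ring, the same change as the one made between compound 1 and compound 2. Given that the single measured example of this change weakened inhibition by an at least 1.5-fold higher number from compound 1 to compound 2 (0.19 log units; that floor lies within the scatter), a step of about a 1.8-fold higher number from compound 3 to compound 4 (0.27 log units; within the scatter) is expected, with a real chance that the assay again reports only a limit. Compound 4 is estimated to give about 35000 nM, within a range of 15000 nM to 90000 nM.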

Compound 4, half-maximal inhibitory concentration: 10800 nM
Compound 4: the middle estimate sits 3.2-fold (0.51 log units) above what was measured; the measured number lies below the stated range.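

On the core of compound 3, putting acetyl in place of hydrogen on the aromatic amino group gives a 1.8-fold lower number from compound 3 to compound 4 (0.25 log units; within the scatter), so in this assay this step alone does not put the two compounds in order. Set beside the same change on the core of compound 1, however, the result shows that this change does not carry from one core to the other with a fixed size, since the two steps differ: the same change on two cores in this assay, an at least 1.5-fold higher number (0.19 log units; that floor lies within the scatter) from compound 1 to compound 2 and a 1.8-fold lower number (0.25 log units; within the scatter) from compound 3 to compound 4, at least 2.7-fold (0.44 log units) apart, beyond the scatter of two such steps. Going by these compounds alone, this does not show which feature of the two cores separates the steps or give a rule for other cores, as it rests on only two pairs of compounds, and compound 2 is reported only as a limit of the assay, > 40000 nM.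

The compounds shown leave open which part of the difference between the two cores matters, as no pair here changes one part of the core while keeping the rest fixed. They also leave open how other groups on the same nitrogen would behave on each core, such as a longer acyl chain like propionyl, a methanesulfonyl group or a simple methyl group.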